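The compounds below may be only part of what the source reports. "The series", "measured", "known", "first", "only" and "open" are said of these compounds alone.

Of the compounds shown here, two built on a shared core have been measured so far. In a functional assay on KB 3-1 cells (Homo sapiens), with a stated time of 1 h (on this read-out higher numbers stand for an effect only at larger amounts of compound and lower numbers for an effect already at smaller amounts), compound 1 (`CCCOc1c(OC)cc2oc(-c3ccccc3)cc(=O)c2c1O`) gives 1200 nM and compound 2 (`CCOc1cc2oc(-c3ccccc3)cc(=O)c2c(O)c1OCC`) gives 1800 nM. Within the data shown here, these two numbers lie within the scatter of each other, so compound 2 stands level with the only other compound measured.

The next compound is compound 3 (`CCOc1c(OC)cc2oc(-c3ccccc3)cc(=O)c2c1O`), which differs from compound 2 in one place: hydrogen in place of methyl on a saturated chain carbon bound to an oxygen on an aromatic ring. In words, hydrogen takes the place of methyl on a saturated chain carbon bound to an oxygen on an aromatic ring, which turns an ethoxy into a methoxy.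

Among the measured compounds shown here, no measured pair differs in a single place, so the data give no direct reading of this change. For the measured compounds named here, the only guide is the narrow span from compound 1 at 1200 nM to compound 2 at 1800 nM. In this assay, the estimated step of a 1.2-fold lower number from compound 2 to compound 3 (0.08 log units; within the scatter) is expected to stay within the scatter, with no clear direction. The expected value for compound 3 is 1500 nM, with an estimated range from 700 nM to 3200 nM.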

Compound 3, half-maximal effective concentration: 1500 nM
Compound 3: middle estimate and measured number agree at the digits printed; the measured number falls inside the stated range.
By their numbers in this assay, from the lowest: compounds 1, 3 and 2 (each within the scatter of the next).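

Among these compounds, compound 3 gives the first direct readings of this change, and it does so on two different chains of the shared core. In this assay, turning an ethoxy into a methoxy gives a 1.2-fold lower number from compound 2 to compound 3 (0.08 log units; within the scatter), while hydrogen in place of methyl on a saturated chain carbon, two bonds along the chain from an oxygen on an aromatic ring, gives a 1.3-fold higher number from compound 1 to compound 3 (0.10 log units; within the scatter), so trimming one carbon from either chain leaves the read-out within the scatter in these two pairs. No measurement shown here offers an explanation for this flat response.

Among the compounds shown here, what the compounds leave open is how far this tolerance extends, since the only changes read are single-carbon ones among short alkyl chains on these oxygens, and a longer chain such as butoxy, a benzyloxy group or a chain ending in an amine or a carboxylic acid could behave differently. On these data alone, the unsubstituted phenyl and the free hydroxyl are the same in all three compounds, so the effect of replacing either of them, for example with a fluorophenyl or a methoxy group, also remains unknown.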